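The source may hold more compounds than are shown below. What is called first, only, known or untested is meant among the compounds shown, and "the series" means these compounds.

The study centers on a shared core carrying a carboxylic acid on one side and a ketone on the other. Compound 1 `Cc1cc(C(=O)O)ccc1OCCCCOc1ccc(C(=O)CC(C)C)c(O)c1C` gives 192 nM in an assay on HEK293 cells for positive allosteric modulation of metabotropic glutamate receptor 2 (Rattus norvegicus), read by thallium flux, with a stated time of 2.5 min (on this read-out lower numbers stand for an effect already at smaller amounts and higher numbers for an effect only at larger amounts of compound), compound 2 `CCCC(=O)c1ccc(OCCCCOc2ccc(C(=O)O)cc2C)c(C)c1O` gives 104 nM, and compound 3 `Cc1cc(C(=O)O)ccc1OCCCCOc1ccc(C(=O)C(C)C)c(O)c1C` gives 234 nM, the highest of the three numbers. Compound 4 `CCC(=O)c1ccc(OCCCCOc2ccc(C(=O)O)cc2C)c(C)c1O` differs from compound 3 by hydrogen in place of methyl on a saturated chain carbon bound to a carbonyl carbon and a saturated chain carbon. For the measured compounds named here, the closest precedent is a 1.8-fold lower number from compound 1 to compound 2 (0.27 log units; within the scatter), which also removed a methyl from a branched chain; the other step, a 2.3-fold higher number from compound 2 to compound 3 (0.35 log units; beyond the scatter), went the opposite way when the branch was added. Compound 4 is therefore expected to give a somewhat lower number, a step of a 1.6-fold lower number from compound 3 to compound 4 (0.19 log units; within the scatter), so compound 4 is estimated at 150 nM, within 70 nM to 320 nM.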

Compound 4, half-maximal effective concentration: 82 nM
Compound 4: the middle estimate sits 1.8-fold (0.26 log units) above what was measured; low and high end bracket the measured number.
By their numbers in this assay, from the lowest: compounds 4, 2, 1 and 3 (each within the scatter of the next, the first and the last beyond it).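

In this assay, the change from isopropyl to ethyl gives a 2.9-fold lower number from compound 3 to compound 4 (0.46 log units; beyond the scatter), and a 2.3-fold lower number from compound 1 to compound 4 (0.37 log units; beyond the scatter) likewise separates the branched isobutyl of compound 1 from the ethyl of compound 4. Among the unbranched chains, however, a 1.3-fold lower number from compound 2 to compound 4 (0.10 log units; within the scatter) leaves no readable difference between compound 2 and compound 4. Removing a methyl now points the same way in two pairs, with steps that agree: the same change on two cores in this assay, a 1.8-fold lower number (0.27 log units; within the scatter) from compound 1 to compound 2 and a 2.9-fold lower number (0.46 log units; beyond the scatter) from compound 3 to compound 4, 1.5-fold (0.19 log units) apart, within the scatter of two such steps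

From the compounds shown here alone, whether a cyclopropyl group or a single methyl on the carbonyl carbon would follow the same direction remains open.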